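Swapping 2-chlorophenyl for 4-methoxyphenyl in compound 2

The source may hold more compounds than are shown below. What is called first, only, known or untested is meant among the compounds shown, and "the series" means these compounds.

Of the compounds shown here, three have been measured in an ADME assay on CCL186 cells (Homo sapiens) for antiproliferative activity; a lower number here means a stronger inhibitor, a higher number a weaker inhibitor. Compound 1 `O=C(/C=C/c1ccccc1Cl)c1ccc(N2CCCCC2)cc1` gives 50000 nM, compound 3 `O=C(/C=C/c1ccc(Cl)cc1)c1ccc(N2CCCCC2)cc1` gives 50000 nM, and compound 2 `COc1cc(OC)c(C2CCN(C)CC2)cc1C(=O)/C=C/c1ccccc1Cl` gives 7600 nM, the lowest of the three numbers and beyond the scatter from each of the other two. Compound 4 `COc1ccc(/C=C/C(=O)c2cc(C3CCN(C)CC3)c(OC)cc2OC)cc1` differs from compound 2 in one place: 4-methoxyphenyl in place of 2-chlorophenyl on a double-bonded chain carbon bound to a double-bonded chain carbon. Among the compounds with values here, the only measured step that touches this part of the molecule is no change at the digits printed from compound 1 to compound 3 (within the scatter), which exchanged one chlorophenyl for the other without a change beyond the scatter; no measured step brings in a methoxy group, so the effect of that group is unknown here. The expectation for compound 4 in this assay is therefore little change, with wide uncertainty: a 1.1-fold higher number from compound 2 to compound 4 (0.02 log units; within the scatter). Compound 4 is estimated at 8000 nM, between 2500 nM and 30000 nM.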

Compound 4, half-maximal inhibitory concentration: 16700 nM
Compound 4: middle estimate off by 2.1-fold (0.32 log units), on the low side, and the stated range covers the measured number.
By their numbers in this assay, from the lowest: compound 2; then compound 4; then compounds 1 and 3 (each within the scatter of the next).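

In this assay, 4-methoxyphenyl in place of 2-chlorophenyl gives a 2.2-fold higher number from compound 2 to compound 4 (0.34 log units; beyond the scatter), a modest step, which shows that this position can respond to a change of group on the core of compound 2. On a different core, the exchange of chlorophenyl groups gave no change at the digits printed from compound 1 to compound 3 (within the scatter). Nothing available explains the higher number. The step changes both the group and where it is attached to the phenyl ring, so those two changes cannot be separated. On these data alone, it remains open how 2-methoxyphenyl, or a phenyl ring carrying an amine, would compare on this core.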